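Bromo-to-hydrogen swap on the aryl ring of a methylene-lactam core

The compounds below may be only part of what the source reports. "The series", "measured", "known", "first", "only" and "open" are said of these compounds alone.

Measured so far:
compound 1 `C=C1CN(C)N(c2ccc(Br)cc2)C1=O` — 43800 nM
compound 2 `C=C1C(=O)N(c2ccccc2)N(C)C1c1ccc(OC)cc1` — 75000 nM

In a functional assay on MCF7 cells (Homo sapiens) for inhibition, read by MTT assay, with a stated time of 48 h (on this read-out higher numbers stand for weaker inhibition and lower numbers for stronger inhibition), compound 1 gives the lowest of the two numbers; compound 2, the nearest, sits within the scatter of it, so the two show no difference beyond the scatter. Compound 3 `C=C1CN(C)N(c2ccccc2)C1=O` is not yet measured. It differs from compound 1 by hydrogen in place of bromo on an aromatic carbon. For the measured compounds named here, no step between measured compounds informs this change, so the expectation for compound 3 is a step from compound 1 of a 1.4-fold higher number from compound 1 to compound 3 (0.14 log units; within the scatter) in this assay, not clearly beyond the scatter, with a slight lean toward a higher number. The estimate for compound 3 is 60000 nM, range 25000 nM to 150000 nM.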

Compound 3, half-maximal inhibitory concentration: 56000 nM
For compound 3 the middle estimate is 1.1-fold (0.03 log units) above the measured one, within the range that was stated.
By their numbers in this assay, from the lowest: compounds 1, 3 and 2 (each within the scatter of the next).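

In this assay, for the compounds shown here, hydrogen in place of bromo on the aromatic carbon gives a 1.3-fold higher number from compound 1 to compound 3 (0.11 log units; within the scatter) and this is the first comparison that changes one place only. Bromo and hydrogen at this carbon cannot be told apart on this read-out, so the bromine atom is not needed for a number of this size.

Open, on these data alone, is whether another group at this carbon, such as an amine, a carboxylic acid or a longer chain, would move the number beyond the scatter. Also open, as far as these compounds go, is whether bromo on the core of compound 2 would read the same. No further data bear on the reason for this result.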